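Aryl sulfonamide series: a pyridyl replacement for the dimethylphenyl

The source may hold more compounds than are shown below. What is called first, only, known or untested is meant among the compounds shown, and "the series" means these compounds.

Measured in a functional assay on DLD-1 cells (Homo sapiens) for antiproliferative activity, read by CellTiter-Glo, with a stated time of 72 h; a lower number here means a stronger inhibitor, a higher number a weaker inhibitor:
compound 1, `Cc1ccc(S(=O)(=O)N2CCC(N3CCC(C)CC3)CC2)cc1C`: 24 nM
compound 2, `CC1CCN(C2CCN(S(=O)(=O)c3sc(Cl)nc3C3CC3)CC2)CC1`: > 5000 nM (a limit of the assay, not a number)

For the measured compounds named here, compound 1 carries the only numerical value in this assay. For compound 2 this assay reports only a limit, (the limit of > 5000 nM in this assay, at which 1 of the 2 values shown sits). Going by the values given here, no step between two measured compounds is available, so the pair gives no measured guide to the size of an aryl change on the sulfonyl sulfur.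

Compound 3, `CC1CCN(C2CCN(S(=O)(=O)c3cncc(Br)c3)CC2)CC1`, differs from compound 1 in one place: 5-bromopyridin-3-yl in place of 3,4-dimethylphenyl on a sulfonyl sulfur. A step in this assay towards weaker inhibition, beyond the usual scatter, is expected: a 6.3-fold higher number from compound 1 to compound 3 (0.80 log units; beyond the scatter). Compound 3 is estimated at 150 nM, within 30 nM to 1500 nM. Among the compounds with values here, the single limit for compound 2 leaves a real chance that compound 3 also returns only a limit.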

Compound 3, half-maximal inhibitory concentration: > 5000 nM
Compound 3: only a limit was reported (the forecaster's own chance of this, stated with the estimate: 20%); middle value at least 33-fold (1.52 log units) from the limit.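

On the sulfonyl sulfur, 5-bromopyridin-3-yl in place of 3,4-dimethylphenyl gives an at least 200-fold higher number from compound 1 to compound 3 (2.31 log units; beyond the scatter) in this assay, so this position now has a measured step from a single change, and that step is large. Going by these compounds, compound 3 gives > 5000 nM, which is a limit of the assay and not a number, so the step is a bound and its full size stays unknown. Of the groups shown on this sulfur, only the 3,4-dimethylphenyl of compound 1 gives a numerical value: the limit of > 5000 nM in this assay, at which 2 of the 3 values shown sit.

The compounds shown do not separate the contribution of the ring nitrogen from that of the bromine or from the loss of the two methyl groups. A 3-bromophenyl or a 5-methylpyridin-3-yl on the sulfonyl sulfur would begin to separate them.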